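Working notes: solubility step from compound 2 to compound 3

The source may hold more compounds than are shown below. What is called first, only, known or untested is meant among the compounds shown, and "the series" means these compounds.

compound 1 `Cn1c(COc2cccc(C(=O)O)c2)nc2ccc(Oc3ccccn3)cc21`: 62 ug/mL
compound 2 `Cc1ccc(Oc2ccc3nc(COc4cccc(C(=O)O)c4)n(C)c3c2)nc1`: 31 ug/mL

In a physicochemical assay for solubility, read by HPLC, measured as thermodynamic solubility, with a stated time of 4 h, at pH 6.8 (on this read-out lower numbers stand for lower solubility and higher numbers for higher solubility), compound 2 gives the lowest of the two numbers; its nearest neighbour is compound 1, and the step of a 2.0-fold lower number from compound 1 to compound 2 (0.30 log units; within the scatter) lies within the scatter. Compound 3 `Cn1c(COc2cccc(C(=O)O)c2)nc2ccc(Oc3ccc(F)cn3)cc21` differs from compound 2 by fluoro in place of methyl on an aromatic carbon. Going by the values given here, the only measured step at this position, a 2.0-fold lower number from compound 1 to compound 2 (0.30 log units; within the scatter), did not leave the scatter, so no change beyond the scatter is expected. Compound 3 is therefore estimated at 45 ug/mL, range 20 ug/mL to 100 ug/mL, an expected step of a 1.5-fold higher number from compound 2 to compound 3 (0.16 log units; within the scatter).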

Compound 3, solubility: 79 ug/mL
Compound 3: the middle estimate sits 1.8-fold (0.24 log units) below what was measured; measured number inside the range.
By their numbers in this assay, from the lowest: compounds 2, 1 and 3 (each within the scatter of the next, the first and the last beyond it).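

In this assay, going by these compounds alone, the change from 5-methylpyridin-2-yl to 5-fluoropyridin-2-yl gives the first step at this position beyond the scatter (a 2.5-fold higher number from compound 2 to compound 3 (0.41 log units; beyond the scatter)). Fluoro in place of hydrogen stays within the scatter (a 1.3-fold higher number from compound 1 to compound 3 (0.11 log units; within the scatter)), so only the methyl and fluoro compounds separate, while compound 1 sits within the scatter of both. No supporting data account for the size of this step.

Open, going by these compounds, is where a chloro group, a methoxy group or an amine at the same place would fall relative to compound 2 and compound 3. Also open, on these data alone, is whether a single step of this size would repeat on repeated measurement.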